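Replacing 4-chlorophenyl with 3-hydroxyphenyl: notes on compound 3

The source may report more compounds than this note shows. Statements on the series, on what has been measured and on what is new or still open speak of the compounds shown alone.

- compound 1 `COc1cccc(/C=C2\CCC/C(=C\c3ccc(Br)cc3)C2=O)c1OC`: > 20000 nM (a limit)
- compound 2 `COc1ccc(/C=C2\CCC/C(=C\c3ccc(Cl)cc3)C2=O)cc1OC`: 10100 nM

Both results come from a functional assay on A549 cells (Homo sapiens) for cytotoxicity, read by MTT assay, with a stated time of 72 h; a lower number here means a stronger inhibitor, a higher number a weaker inhibitor. Compound 1 gives > 20000 nM, which is a limit of the assay and not a number. For the measured compounds named here, compound 2, at 10100 nM, holds the only actual number so far, so its standing cannot be fixed against a second measured value.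

Compound 3 `COc1ccc(/C=C2\CCC/C(=C\c3cccc(O)c3)C2=O)cc1OC` has not yet been measured. It carries 3-hydroxyphenyl in place of 4-chlorophenyl on a double-bonded chain carbon bound to a double-bonded ring carbon. The rest of the structure matches compound 2.

Going by the values given here, no measured pair differs in one place only, so the data give no size or direction for this change. The expectation is therefore no step beyond the scatter in this assay, in either direction, and the range is kept wide. The expected step is a 1.1-fold higher number from compound 2 to compound 3 (0.04 log units; within the scatter). Compound 3 is estimated at 11000 nM, with an expected range of 4000 nM to 28000 nM.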

Compound 3, half-maximal inhibitory concentration: 4300 nM
The estimate for compound 3 lay 2.6-fold (0.41 log units) above the measured number, within the range that was stated.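

In this assay the series gets its first reading of a change at this place: 3-hydroxyphenyl in place of 4-chlorophenyl on a double-bonded chain carbon bound to a double-bonded ring carbon gives a 2.3-fold lower number from compound 2 to compound 3 (0.37 log units; beyond the scatter) with the rest of the structure unchanged. This place therefore responds to the group it carries, and the direction favours the entering group, which has a hydrogen-bond donor and acceptor where 4-chlorophenyl has neither, though one step assigns no cause. Both ends of this step are actual numbers, and the only value at the limit of the assay belongs to compound 1, which differs from compound 2 in more than one place, so steps involving compound 1 cannot be read: the limit of > 20000 nM in this assay, at which 1 of the 3 values shown sits.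

The step swaps the substituent and its place on the phenyl ring together, so the compounds shown cannot say which of the two carries the change; 4-hydroxyphenyl or 3-chlorophenyl would separate them. As far as these compounds go, whether the trend extends to other groups at this place, such as an amine or a carboxylic acid on the phenyl ring, also remains open.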